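The source may report more compounds than this note shows. Statements on the series, on what has been measured and on what is new or still open speak of the compounds shown alone.

Compound 1, `NC1=NC2(CCOCC2)N(OCCCOc2cccc(Cl)c2)C(N)=N1`, gives 150 nM in a functional assay on HepG2 cells (Homo sapiens) for antiproliferative activity, read by MTT assay, with a stated time of 72 h; a lower number here means a stronger inhibitor, a higher number a weaker inhibitor.
Compound 2, `NC1=NC2(CCOCC2)N(OCCCOc2ccc(Cl)c(Cl)c2)C(N)=N1`, gives 380 nM in this assay.
Compound 3, `NC1=NC2(CCOCC2)N(OCCCOc2cc(Cl)c(Cl)cc2Cl)C(N)=N1`, has no reported result; in this assay compound 3 stands as "not determined" (no result reported).

Three compounds sharing one core were tested in this assay, and only two of them returned a number. Compound 1 stands at the lowest of those two numbers; its nearest neighbour is compound 2, and the step of a 2.5-fold higher number from compound 1 to compound 2 (0.40 log units; beyond the scatter) goes beyond the usual scatter, so compound 1 is the stronger of the pair. Compound 3 carries a third chloro on the ring but was not measured.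

Compound 4, `NC1=NC2(CCOCC2)N(OCCCOc2ccccc2Cl)C(N)=N1`, is the next compound of interest. It differs from compound 1 only in this way: 2-chlorophenyl in place of 3-chlorophenyl on an oxygen on a saturated carbon. Within the data shown here, the one measured step, from compound 1 to compound 2, added a chloro and weakened the inhibitor modestly; it does not tell how moving the single chloro to another place on the ring would read. Among the measured compounds shown here, with no closer precedent, the step to compound 4 is expected to be small, a 1.5-fold higher number from compound 1 to compound 4 (0.17 log units; within the scatter), and compound 4 is estimated at 220 nM, within 80 nM to 600 nM.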

Compound 4, half-maximal inhibitory concentration: 1750 nM
Compound 4: the middle estimate sits 8.0-fold (0.90 log units) below what was measured; the whole stated range lies below it.
By their numbers in this assay, from the lowest: compound 1; then compound 2; then compound 4.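

In this assay, where the single chloro sits on the ring matters: 2-chlorophenyl in place of 3-chlorophenyl is a large step (a 12-fold higher number from compound 1 to compound 4 (1.07 log units; beyond the scatter)), even though no atom is gained or lost, while adding a second chloro to compound 1 was only a modest one (a 2.5-fold higher number from compound 1 to compound 2 (0.40 log units; beyond the scatter)). Counting chloro groups therefore does not set the order among these compounds, since the 3,4-dichlorophenyl of compound 2 still reads stronger than the single 2-chlorophenyl (a 4.6-fold higher number from compound 2 to compound 4 (0.66 log units; beyond the scatter)). Nothing shown here explains why this move costs so much.

As far as these compounds go, it remains open whether a fluoro or a methoxy group in place of the chloro of compound 4 would carry the same penalty. Also open, from the compounds shown here alone, is whether a longer chain to the oxygen would change the size of this step.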